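Swapping the Piperidine Chain for a Methylphenyl Group

A few compounds are considered here, and "the series" means these few. Any claim that something is new, unique, unknown or untested is made for them only; others in the source may bear on it.

Of the compounds shown here, three built on one shared core have been measured in an assay on CHO-K1 cells for antagonist activity at transient receptor potential cation channel subfamily V member 1 (Homo sapiens), read by FLIPR; on this read-out higher numbers stand for weaker inhibition and lower numbers for stronger inhibition. Compound 1 `CC(C(=O)NCc1ccc(C(F)(F)F)nc1SCCOc1ccccc1)c1ccc(NS(C)(=O)=O)c(F)c1` gives 2.3 nM. Compound 2 `CC(C(=O)NCc1ccc(C(F)(F)F)nc1SCCCN1CCCCC1)c1ccc(NS(C)(=O)=O)c(F)c1` gives 3 nM, the second highest of the three numbers; it stands nearest to compound 1, a 1.3-fold higher number from compound 1 to compound 2 (0.12 log units; within the scatter), and furthest from compound 3 `CC(C(=O)NCc1ccc(C(F)(F)F)nc1SCc1ccc(Cl)cc1)c1ccc(NS(C)(=O)=O)c(F)c1`, which gives 8.7 nM.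

Compound 4 `Cc1ccc(CSc2nc(C(F)(F)F)ccc2CNC(=O)C(C)c2ccc(NS(C)(=O)=O)c(F)c2)cc1` has not yet been measured. It differs from compound 2 in a single place: 4-methylphenyl in place of 2-(piperidin-1-yl)ethyl on a saturated chain carbon bound to a sulfur. Going by the values given here, two measured steps bear on this change. The closest is the move from compound 2 to compound 3, a 2.9-fold higher number from compound 2 to compound 3 (0.46 log units; beyond the scatter), where the same 2-(piperidin-1-yl)ethyl group gave way to 4-chlorophenyl on the saturated chain carbon bound to a sulfur. The related step of a 3.8-fold higher number from compound 1 to compound 3 (0.58 log units; beyond the scatter) points the same way. In both cases, placing a six-membered aromatic ring of carbon only at that carbon raised the number by a modest amount. Since compound 4 carries 4-methylphenyl rather than 4-chlorophenyl at that carbon, a step of similar size and the same direction is expected, a 2.7-fold higher number from compound 2 to compound 4 (0.43 log units; beyond the scatter). Compound 4 is therefore estimated at 8 nM, with a range from 3.5 nM to 20 nM.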

Compound 4, inhibition constant: 3.2 nM
Compound 4: the middle estimate sits 2.5-fold (0.40 log units) above what was measured; measured number outside the range, below it.
By their numbers in this assay, from the lowest: compounds 1, 2 and 4 (each within the scatter of the next); then compound 3.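

In this assay, the 4-methylphenyl group at the saturated chain carbon bound to a sulfur stands level with both longer groups, within the scatter of 2-(piperidin-1-yl)ethyl (a 1.1-fold higher number from compound 2 to compound 4 (0.03 log units; within the scatter)) and of phenoxymethyl (a 1.4-fold higher number from compound 1 to compound 4 (0.14 log units; within the scatter)), so a six-membered aromatic ring of carbon only at that carbon does not by itself raise the number. The rise seen earlier with compound 3 therefore goes with the ring's chloro group in this set: methyl in place of chloro on an aromatic carbon is a single change, and it lowers the number by a modest step beyond the scatter (a 2.7-fold lower number from compound 3 to compound 4 (0.43 log units; beyond the scatter)). Nothing measured here accounts for this difference between methyl and chloro.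

Whether an unsubstituted phenyl, a 4-fluorophenyl or a 4-methoxyphenyl group would stand with compound 4 or with compound 3 remains open, and the two ring substituents shown cannot settle it. Also open, as far as these compounds go, is whether a morpholine or a free amine at the end of the chain in compound 2 would stay level with the piperidine.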